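The source may report more compounds than this note shows. Statements on the series, on what has been measured and on what is new or still open speak of the compounds shown alone.

Measured in a functional assay on EBC-1 cells (Homo sapiens) for antiproliferative activity, with a stated time of 72 h; on this read-out lower numbers stand for stronger inhibition and higher numbers for weaker inhibition:
- Compound 1 `N#Cc1cccc(-c2cc(F)c3ncc(Cc4ccc5ncccc5c4)n3c2)c1`: 107 nM
- Compound 2 `N#Cc1ccc(-c2cc(F)c3ncc(Cc4ccc5ncccc5c4)n3c2)cc1F`: 145 nM
- Compound 3 `COc1ccc(-c2cc(F)c3ncc(Cc4ccc5ncccc5c4)n3c2)cc1F`: 407 nM

Compound 3 is the weakest of the three, and its steps to both others lie beyond the scatter. Compound 4 `O=C(c1ccc(-c2cc(F)c3ncc(Cc4ccc5ncccc5c4)n3c2)cc1F)N1CCC2(COC2)C1` keeps the shared core and the fluoro group but loses the methoxy of compound 3 (a group of 10 heavy atoms (7 carbon, 1 nitrogen, 2 oxygen; one four-membered non-aromatic ring with 1 hetero atom, one five-membered non-aromatic ring with 1 hetero atom) in place of a group of 2 heavy atoms (1 carbon, 1 oxygen; no ring), on an aromatic carbon). The change falls on an aromatic carbon, ortho to a fluoro group and para to a large group.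

For the measured compounds named here, two measured steps bear on this change: a 2.8-fold higher number from compound 2 to compound 3 (0.45 log units; beyond the scatter), with methoxy in place of cyano, and a 3.8-fold higher number from compound 1 to compound 3 (0.58 log units; beyond the scatter). Both are modest. The third, a 1.4-fold higher number from compound 1 to compound 2 (0.13 log units; within the scatter), lies within the scatter. Going by the values given here, no measured compound carries a group as large as the one entering, so the size of the step remains uncertain.

With compound 3 at 407 nM as the highest number here, a modest move to a lower number is expected in this assay. The expected change is a 2.4-fold lower number from compound 3 to compound 4 (0.38 log units; beyond the scatter). For compound 4 the estimated value is 170 nM, with an expected range from 50 nM to 550 nM.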

Compound 4, half-maximal inhibitory concentration: 406 nM
Compound 4: the middle estimate sits 2.4-fold (0.38 log units) below what was measured; the measured number falls inside the stated range.
By their numbers in this assay, from the lowest: compounds 1 and 2 (each within the scatter of the next); then compounds 4 and 3 (each within the scatter of the next).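

In this assay, for the compounds shown here, the earlier compounds carried only small groups on this aromatic carbon, and the large group with its four-membered and five-membered non-aromatic rings now gives a 1.0-fold lower number from compound 3 to compound 4 (0.00 log units; within the scatter) and so cannot be told apart from methoxy here. Against the nitrile, the large group shows a 2.8-fold higher number from compound 2 to compound 4 (0.45 log units; beyond the scatter) and methoxy shows a 2.8-fold higher number from compound 2 to compound 3 (0.45 log units; beyond the scatter) in the same way, so neither brings back the lower number. Nothing given here accounts for this result. As far as these compounds go, whether an amine, a carboxylic acid or a plain open-chain amide without the two rings on this carbon would come nearer to compound 2 stays open. Also open, from the compounds shown here alone, is whether the large group would hold this standing without the fluoro group on its ring.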